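Thiophenyl for Ethynyl on a Methylsulfanyl Core

The source may hold more compounds than are shown below. What is called first, only, known or untested is meant among the compounds shown, and "the series" means these compounds.

Three nucleoside analogues have been measured in a functional assay on K562 cells (Homo sapiens), read by MTT assay, with a stated time of 72 h; on this read-out lower numbers stand for stronger inhibition and higher numbers for weaker inhibition. Compound 2 `C#Cc1cn([C@@H]2O[C@H](CO)[C@@H](O)[C@H]2O)c2ncnc(OC)c12` carries an ethynyl group and a methoxy group; in this assay compound 2 gives 300 nM. Compound 1 `COc1ncnc2c1c(-c1ccsc1)cn2[C@@H]1O[C@H](CO)[C@@H](O)[C@H]1O` differs from it by the change (thiophen-3-yl in place of ethynyl on an aromatic carbon), and in this assay compound 1 gives 90 nM, a step of a 3.3-fold lower number from compound 2 to compound 1 (0.52 log units; beyond the scatter). Compound 3 `C#Cc1cn([C@@H]2O[C@H](CO)[C@@H](O)[C@H]2O)c2ncnc(SC)c12` differs from compound 2 by the change (methylsulfanyl in place of methoxy on an aromatic carbon), and in this assay compound 3 gives 30 nM, a step of a 10-fold lower number from compound 2 to compound 3 (1.00 log units; beyond the scatter). Compound 3 thus stands lowest of the three measured numbers, with compound 1 nearest and compound 2 furthest.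

Compound 4 `CSc1ncnc2c1c(-c1ccsc1)cn2[C@@H]1O[C@H](CO)[C@@H](O)[C@H]1O` has not yet been measured. It differs from compound 3 by thiophen-3-yl in place of ethynyl on an aromatic carbon. This is the same change that was made from compound 2 to compound 1, occurring twice among the four compounds, and the surroundings of the place are described in the same terms for both pairs. If the step seen from compound 2 to compound 1 carries over onto the core of compound 3, compound 4 is expected to show a step of about a 3.0-fold lower number from compound 3 to compound 4 (0.48 log units; beyond the scatter), though with only one earlier example of this change the carry-over is uncertain. Compound 4 is therefore estimated at 10 nM, with a likely range from 3 nM to 35 nM.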

Compound 4, half-maximal inhibitory concentration: 450 nM
Compound 4: middle estimate off by 45-fold (1.65 log units), on the low side; the whole stated range lies below it.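

In this assay, thiophen-3-yl in place of ethynyl on the core of compound 3 gives a 15-fold higher number from compound 3 to compound 4 (1.18 log units; beyond the scatter), opposite in direction to the step on the core of compound 2, so the change does not carry from one core to the other: the same change on two cores in this assay, a 3.3-fold lower number (0.52 log units; beyond the scatter) from compound 2 to compound 1 and a 15-fold higher number (1.18 log units; beyond the scatter) from compound 3 to compound 4, 50-fold (1.70 log units) apart, beyond the scatter of two such steps. The second change in these four compounds behaves in the same way, with methylsulfanyl in place of methoxy giving a 5.0-fold higher number from compound 1 to compound 4 (0.70 log units; beyond the scatter), whereas it gave a lower number on the ethynyl-bearing core: the same change on two cores in this assay, a 10-fold lower number (1.00 log units; beyond the scatter) from compound 2 to compound 3 and a 5.0-fold higher number (0.70 log units; beyond the scatter) from compound 1 to compound 4, 50-fold (1.70 log units) apart, beyond the scatter of two such steps. Among the compounds shown here, the two changes therefore do not add up across these four compounds, but the data do not show what lies behind this, and with only two cores for each change they do not show how either change would behave on a third core.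

The compounds shown leave open whether the rise in the number belongs to thiophen-3-yl alone or would also appear with another group at the same place, such as a phenyl ring, a furan-3-yl ring or a plain methyl. They also leave open how such groups would behave with an amine or an ethylsulfanyl chain in place of methylsulfanyl.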